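The compounds below may be only part of what the source reports. "The series", "measured", "known", "first", "only" and "open" are said of these compounds alone.

In a functional assay on HCT-116 cells (Homo sapiens) for antiproliferative activity, read by MTT assay, with a stated time of 72 h (a lower number here means a stronger inhibitor, a higher number a weaker inhibitor), compound 1 `O=C(CCc1cccc2c1B(O)OC2)Nc1cccc(I)c1` gives 2300 nM, while compound 2 `O=C(CCc1cccc2c1B(O)OC2)Nc1cccc(-c2ccccc2)c1` gives 890 nM, the lower of the two numbers. Compound 3 `O=C(CCc1cccc2c1B(O)OC2)Nc1cccc(-c2cccc(OC(F)(F)F)c2)c1` departs from compound 2 at a single place: trifluoromethoxy in place of hydrogen on an aromatic carbon. This puts trifluoromethoxy in place of hydrogen on an aromatic carbon, meta to a large group. For the measured compounds named here, only one measured step offers any guide, a 2.6-fold lower number from compound 1 to compound 2 (0.41 log units; beyond the scatter), which is modest but beyond the scatter. That step exchanges iodo for phenyl, so it says nothing direct about trifluoromethoxy and gives only weak support for a further fall. In this assay, no step beyond the scatter is therefore expected, with a slight lean towards a lower number. For compound 3, the expected value is 700 nM, with an estimated range of 250 nM to 1900 nM. The estimated change is a 1.3-fold lower number from compound 2 to compound 3 (0.10 log units; within the scatter).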

Compound 3, half-maximal inhibitory concentration: 310 nM
Compound 3: the middle estimate sits 2.3-fold (0.35 log units) above what was measured; the range from low to high includes it.
By their numbers in this assay, from the lowest: compound 3; then compound 2; then compound 1.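

In this assay, trifluoromethoxy in place of hydrogen on an aromatic carbon, meta to a large group, gives a 2.9-fold lower number from compound 2 to compound 3 (0.46 log units; beyond the scatter). The earlier step only exchanged iodo for phenyl on the shared core, whereas this one shows that the phenyl of compound 2 can itself take a substituent and that the number falls again, by a modest amount. Nothing measured here bears on the reason for this step.

As far as these compounds go, whether the fall belongs to trifluoromethoxy in particular remains open, since a methoxy, a fluoro, an amine or a carboxylic acid at this same place could lower the number as well or raise it. From the compounds shown here alone, it is also open whether trifluoromethoxy would give a similar step on another carbon of that ring.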